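Adding a hydroxy to compound 3

A few compounds are considered here, and "the series" means these few. Any claim that something is new, unique, unknown or untested is made for them only; others in the source may bear on it.

Measured in a functional assay on K562 cells (Homo sapiens) for antiproliferative activity, read by MTT assay, with a stated time of 48 h; on this read-out lower numbers stand for stronger inhibition and higher numbers for weaker inhibition:
- compound 1 `Oc1ccc2c(c1)CCc1ccc(O)c(c1)Oc1ccc(cc1O)CCc1cccc(O)c1O2`: 25300 nM
- compound 2 `Oc1ccc2cc1Oc1ccc(cc1)/C=C\c1cccc(O)c1Oc1ccccc1CC2`: 19200 nM
- compound 3 `Oc1ccc2cc1Oc1ccc(cc1)CCc1cccc(O)c1Oc1ccc(cc1)CC2`: 8520 nM

Compound 3 gives 8520 nM, the lowest of the three numbers, and the values of the other two compounds lie beyond the scatter from it. Next in line is compound 4 `Oc1ccc2cc1Oc1ccc(cc1)CCc1cccc(O)c1Oc1ccc(cc1O)CC2`, which differs from compound 3 by a hydroxy in place of hydrogen on an aromatic carbon. That carbon sits in a six-membered aromatic ring of carbon only, part of a fused or bridged system of five rings.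

Going by the values given here, no two measured compounds differ in one place, so the series gives no direct measure of this change. Among the compounds with values here, the only guide is that compound 2 at 19200 nM and compound 1 at 25300 nM both stand higher than compound 3, which is weak support for a slight upward move. The expected step, a 1.3-fold higher number from compound 3 to compound 4 (0.11 log units; within the scatter), is small, towards weaker inhibition and within the scatter. Compound 4 is estimated at 11000 nM, with an expected range of 4000 nM to 28000 nM.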

Compound 4, half-maximal inhibitory concentration: 24900 nM
Compound 4: middle estimate off by 2.3-fold (0.35 log units), on the low side; low and high end bracket the measured number.
By their numbers in this assay, from the lowest: compound 3; then compounds 2, 4 and 1 (each within the scatter of the next).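

Placing a hydroxy in place of hydrogen on an aromatic carbon gives the first single-change measure in the series, in this assay: a 2.9-fold higher number from compound 3 to compound 4 (0.47 log units; beyond the scatter). The step runs towards weaker inhibition and lies beyond the scatter, so this carbon of the six-membered aromatic ring, ortho to a fused ring and meta to a fused ring, does not accept the added hydroxy without a loss, at least for this one pair. No measurement at hand accounts for the step.

The compounds shown leave open whether the loss belongs to the hydroxy itself or to any group on this carbon, which a methoxy or a fluorine at the same place could separate. They also leave open whether a hydroxy on another aromatic carbon of the core would give a step of similar size.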